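This account rests on a few compounds, and the source may have more. Where it says the series, first, only, none or still open, it means among the compounds named here.

Working notes on the series.

Three compounds have numbers in an assay on HL-60 cells for inhibition of glutathione S-transferase P (Homo sapiens), read by spectrophotometry, tested at 20 uM; a lower number here means less inhibition, a higher number more inhibition at the concentration tested (going by the name of the read-out). Compound 1, `Cc1ccc2c(c1)C(=O)/C(=C/c1ccccc1)CN2CC(=O)O`, gives 4.23%. Compound 2, `Cc1cccc2c1N(CC(=O)O)C/C(=C\c1cccc(O)c1)C2=O`, gives 75.6%. Compound 3, `CCOc1ccc(/C=C2\CN(CC(=O)O)c3c(Cl)cccc3C2=O)cc1`, gives 59.1%. Compound 2 stands highest of the three; its nearest neighbour is compound 3, lower by a margin beyond the scatter, and compound 1 lies furthest below it, also beyond the scatter. Going by the values given here, no two measured compounds differ in a single place, so no step between measured compounds can be read directly.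

Compound 4, `COc1ccc(/C=C2\CN(CC(=O)O)c3c(C)cccc3C2=O)cc1`, has not been measured in this assay. Relative to compound 2 it carries 4-methoxyphenyl in place of 3-hydroxyphenyl on a double-bonded chain carbon bound to a double-bonded ring carbon. The hydroxyl donor of compound 2 is gone and an alkoxy group of a different pattern enters; compound 3, which also carries an alkoxy group on that ring, gives 59.1% in this assay. On that basis a downward step is expected, beyond the scatter, for compound 4 relative to compound 2: the expected step is a number 25.6 percentage points lower from compound 2 to compound 4 (beyond the scatter). The estimate for compound 4 in this assay is 50%, with a range from 25% to 75%.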

Compound 4, a percentage reported as inhibition, at one concentration (the size of the read-out at that concentration, not a potency): 31.5%
Estimate against measurement, compound 4: 18.5 percentage points above; low and high end bracket the measured number.
By their numbers in this assay, from the lowest: compound 1; then compound 4; then compound 3; then compound 2.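

Going by these compounds alone, replacing 3-hydroxyphenyl with 4-methoxyphenyl on a double-bonded chain carbon bound to a double-bonded ring carbon gives a number 44.1 percentage points lower from compound 2 to compound 4 (beyond the scatter) in this assay, the first step that can be read directly. The read-out at this place therefore responds strongly to the group carried there, at least for this pair. The entering group has no hydrogen-bond donor where the leaving group has one, and it also differs in its substitution pattern and its heavy-atom count, so this single step does not separate those changes; nothing at hand gives a cause for the drop.

Going by these compounds, whether the hydroxyl, the methoxy or the ring pattern drives the step remains open, and 3-methoxyphenyl and 4-hydroxyphenyl at the same place would separate them. On these data alone, how an amine or a carboxylic acid on that phenyl ring would read in this assay also remains open.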